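The source may report more compounds than this note shows. Statements on the series, on what has been measured and on what is new or still open speak of the compounds shown alone.

Of the compounds shown here, two have been measured so far in a functional assay on HCT-116 cells (Homo sapiens) for inhibition, read by MTT assay, with a stated time of 48 h; a higher number here means a weaker inhibitor, a lower number a stronger inhibitor. Compound 1 `CCC/C=C/C(=O)N(Cc1ccc(OC)c(O)c1)c1cc(OC)c(OC)c(OC)c1` gives 95 nM and holds the lowest number of the two; compound 2 `C/C=C/C(=O)N(Cc1ccc(OC)c(Br)c1)c1cc(OC)c(OC)c(OC)c1` gives 2800 nM, a much higher figure, though it differs from compound 1 in more than one place, so the two values show only that the gap between them is real and not which change carries it. Compound 3 `COc1ccc(CN(C(=O)C2CC2)c2cc(OC)c(OC)c(OC)c2)cc1O` has not yet been measured in this assay. It departs from compound 1 in a single spot, (cyclopropyl in place of pent-1-en-1-yl on a carbonyl carbon). Among the compounds with values here, no measured pair in this set isolates such a change at the carbonyl carbon, so nothing already in hand fixes the size of the step. The expectation is a moderate rise in the number, beyond the scatter, giving an estimated step of a 3.2-fold higher number from compound 1 to compound 3 (0.50 log units; beyond the scatter). For compound 3 the estimate in this assay is 300 nM, with a range from 80 nM to 1200 nM.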

Compound 3, half-maximal inhibitory concentration: 49 nM
Compound 3: the middle estimate sits 6.1-fold (0.79 log units) above what was measured; measured number below the stated range.
By their numbers in this assay, from the lowest: compounds 3 and 1 (each within the scatter of the next); then compound 2.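

Exchanging pent-1-en-1-yl for cyclopropyl on a carbonyl carbon whose other neighbour is the amide-type nitrogen gives a 1.9-fold lower number from compound 1 to compound 3 (0.29 log units; within the scatter) in this assay, so the two compounds read alike. For this pair, then, neither the open chain nor its double bond is needed to hold a number of this size, and a three-membered ring of carbon only, with fewer heavy atoms, serves equally well at this place. The data shown offer no measured basis for explaining why the two groups read alike.

The compounds shown leave open whether a cyclobutyl ring, a phenyl group or a longer chain on the same carbonyl carbon would read alike. On these data alone, whether the same exchange gives a similar step on a core carrying other groups also remains open.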